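This account rests on a few compounds, and the source may have more. Where it says the series, first, only, none or still open, it means among the compounds named here.

In a physicochemical assay for lipophilicity, read by LC-MS, in phosphate buffer, measured as octanol-water partition, with a stated time of 30 min, at pH 7.4, tested at 200 mM (on this read-out lower numbers stand for lower lipophilicity and higher numbers for higher lipophilicity), compound 1 `Cc1ccc(Oc2ccc3nc(COc4cccc(C(=O)O)c4)n(C)c3n2)cc1C` gives 2.2. Compound 2 `Cc1cccc(Oc2ccc3nc(COc4cccc(C(=O)O)c4)n(C)c3c2)n1` gives 0.8, the lower of the two numbers at hand. The gap between these two numbers lies well beyond the scatter. Compound 3 `Cc1ccc(C)c(Oc2ccc3nc(COc4cccc(C(=O)O)c4)n(C)c3c2)n1` differs from compound 2 by a single change, methyl in place of hydrogen on an aromatic carbon, ortho to a large group. Among the measured compounds shown here, no measured pair shows this change, so the expectation rests on the added methyl alone. A modest upward move in this assay is expected, with the estimated a number 0.40 log units higher from compound 2 to compound 3 (beyond the scatter) only just clearing the scatter. Compound 3 is expected at 1.2, with an estimated range of 0.8 to 1.7.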

Compound 3, distribution coefficient: 1.4
Estimate against measurement, compound 3: 0.20 log units below; measured number inside the range.
By their numbers in this assay, from the lowest: compound 2; then compound 3; then compound 1.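

In this assay, among the compounds shown here, methyl on this aromatic carbon, ortho to a large group and para to a methyl group, gives a number 0.60 log units higher from compound 2 to compound 3 (beyond the scatter), the first measured step for this change. It shows that (3,6-dimethylpyridin-2-yl)oxy stands apart from (6-methylpyridin-2-yl)oxy by a modest step that still lies beyond the scatter. No measurement at hand accounts for the size of this step. The compounds shown leave open how an amine, a fluorine atom or a longer chain at this position would read, and whether methyl on another carbon of this ring would give a similar step.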